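The compounds below may be only part of what the source reports. "The series", "measured", "known", "first", "only" and "open" are said of these compounds alone.

Values in a functional assay on HepG2 cells (Homo sapiens) for cytotoxicity, read by MTT assay, with a stated time of 72 h; a lower number here means a stronger inhibitor, a higher number a weaker inhibitor:
compound 1 `CNC(=O)c1cc(Oc2ccc(C3=NNC(c4ccc(Cl)cc4Cl)C3)cc2)ccn1`: "not determined" (no result reported)
compound 2 `CNC(=O)c1cc(Oc2ccc(C3=NNC(c4cc(OC)c(OC)c(OC)c4)C3)cc2)ccn1`: 24300 nM
compound 3 `CNC(=O)c1cc(Oc2ccc(C3=NNC(c4ccc(F)cc4Cl)C3)cc2)ccn1`: 11500 nM

Only two of these compounds have numbers, and compound 3 has the lower one, so it is the stronger inhibitor of the pair by a margin beyond the scatter. Compound 1 has no result to compare.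

Next is compound 4 `CNC(=O)c1cc(Oc2ccc(C3=NNC(c4ccc(OC)cc4)C3)cc2)ccn1`, not yet measured in this assay. The change from compound 3 is 4-methoxyphenyl in place of 2-chloro-4-fluorophenyl on a saturated ring carbon. Going by the values given here, no measured pair differs in one place, so no direct step guides the estimate. The closest reference is compound 2, which also carries methoxy groups on this aryl ring and gives 24300 nM. This points to a small move toward a higher number, which may not clear the scatter. The estimated change is a 1.6-fold higher number from compound 3 to compound 4 (0.19 log units; within the scatter). For compound 4 the expected value is 18000 nM, with an estimated range of 8000 nM to 40000 nM.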

Compound 4, half-maximal inhibitory concentration: 9640 nM
The estimate for compound 4 lay 1.9-fold (0.27 log units) above the measured number; the range from low to high includes it.
By their numbers in this assay, from the lowest: compounds 4 and 3 (each within the scatter of the next); then compound 2.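

Going by these compounds alone, the first direct step at this position, 4-methoxyphenyl in place of 2-chloro-4-fluorophenyl on the saturated ring carbon, gives a 1.2-fold lower number from compound 3 to compound 4 (0.08 log units; within the scatter) in this assay. For this one pair, the two aryl groups cannot be told apart in this read-out, so neither the chlorine nor the fluorine of compound 3 is needed for a number at this level. No available data explain this result or link it to any property of either group.

Going by these compounds, it remains open whether this insensitivity extends beyond these aryl groups, for example to a phenyl ring carrying a carboxylic acid or a dimethylamino group, or to a longer alkyl chain on the same carbon. A single pair also cannot show whether the same holds for other aryl groups at this position.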